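A few compounds are considered here, and "the series" means these few. Any claim that something is new, unique, unknown or untested is made for them only; others in the source may bear on it.

Measured compounds in a functional assay on HT-29 cells (Homo sapiens) for cytotoxicity, read by MTT assay, with a stated time of 72 h; on this read-out lower numbers stand for stronger inhibition and higher numbers for weaker inhibition:

Compound 1 `CN(C)CCn1cnnc1-c1cc(Oc2ccc(NC(=O)N/N=C/c3ccc(Cl)cc3Cl)cc2F)ccn1` gives 390 nM.
Compound 2 `CN(C)CCn1cnnc1-c1cc(Oc2ccc(NC(=O)N/N=C/c3c[nH]c4ccccc34)cc2F)ccn1` gives 1300 nM.
Compound 3 `CN(C)CCn1cnnc1-c1cc(Oc2ccc(NC(=O)N/N=C/c3c(O)ccc4ccccc34)cc2F)ccn1` gives 670 nM.

Compound 3 stands second highest of these three numbers, but its step to compound 1, a 1.7-fold higher number from compound 1 to compound 3 (0.24 log units; within the scatter), and its step from compound 2, a 1.9-fold lower number from compound 2 to compound 3 (0.29 log units; within the scatter), both lie within the scatter, so the three share one shared core and differ only in the group on the carbon with a double bond to nitrogen. Within the data shown here, the only step beyond the scatter is a 3.3-fold higher number from compound 1 to compound 2 (0.52 log units; beyond the scatter), a modest one.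

Compound 4 `COc1ccc(/C=N/NC(=O)Nc2ccc(Oc3ccnc(-c4nncn4CCN(C)C)c3)c(F)c2)cc1O` changes that same position: 3-hydroxy-4-methoxyphenyl in place of 2-hydroxynaphthalen-1-yl on a carbon with a double bond to nitrogen. Among the measured compounds shown here, the steps that bear on it are the three swaps at this carbon, of which two stayed within the scatter and one was modest. A change of similar kind is therefore expected to move this assay little, with no clear direction.

For compound 4 the estimate is 650 nM, with a range from 250 nM to 1700 nM, which means an expected step of a 1.0-fold lower number from compound 3 to compound 4 (0.01 log units; within the scatter).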

Compound 4, half-maximal inhibitory concentration: 960 nM
The estimate for compound 4 lay 1.5-fold (0.17 log units) below the measured number; the range from low to high includes it.
By their numbers in this assay, from the lowest: compounds 1, 3, 4 and 2 (each within the scatter of the next, the first and the last beyond it).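

In this assay, swapping 2-hydroxynaphthalen-1-yl, with its two aromatic rings, for the single ring of 3-hydroxy-4-methoxyphenyl leaves the number within the scatter (a 1.4-fold higher number from compound 3 to compound 4 (0.16 log units; within the scatter)), and the swap from 1H-indol-3-yl does the same (a 1.4-fold lower number from compound 2 to compound 4 (0.13 log units; within the scatter)). Compound 1 and compound 4 each carry one aromatic ring at this carbon, yet their step lies beyond the scatter, though it is modest (a 2.5-fold higher number from compound 1 to compound 4 (0.39 log units; beyond the scatter)), so the count of rings alone does not set the number, and what the ring carries may also count. No measurement here explains these differences.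

Still open, as far as these compounds go, is how a group with no aromatic ring, such as an amine or a carboxylic acid on a short chain, would behave on this carbon. Also open, from the compounds shown here alone, is what the hydroxy and the methoxy of compound 4 each contribute alone.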